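Methyl in place of fluoro on a fused thiourea core

A few compounds are considered here, and "the series" means these few. Any claim that something is new, unique, unknown or untested is made for them only; others in the source may bear on it.

Measured compounds in a functional assay on U-937 cells (Homo sapiens) for cytotoxicity, read by MTT assay, with a stated time of 48 h; on this read-out higher numbers stand for weaker inhibition and lower numbers for stronger inhibition:
- Compound 1, `Fc1ccc2nc(NC(=S)Nc3ccc(Cl)cc3)sc2c1`, gives 18700 nM
- Compound 2, `Fc1ccc(NC(=S)Nc2nc3ccc(F)cc3s2)cc1`, gives 16200 nM
- Compound 3, `Fc1ccc2nc(Nc3nc4c(Cl)cccc4s3)sc2c1`, gives 50000 nM

Compound 2 has the lowest number of the three, but its gap to compound 1 is within the scatter, so the two cannot be told apart; only compound 3 stands clearly higher. For the measured compounds named here, the single step between compounds that differ in one place, a 1.2-fold lower number from compound 1 to compound 2 (0.06 log units; within the scatter), swaps one halogen for another on the anilino side and leaves the read-out essentially unchanged.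

Compound 4, `Cc1ccc2nc(NC(=S)Nc3ccc(F)cc3)sc2c1`, is not yet measured. It differs from compound 2 in one place: methyl in place of fluoro on an aromatic carbon. Going by the values given here, no measured step touches this part of the shared core, so nothing here shows how a methyl in that place compares with a fluoro. Among the compounds with values here, the one measured step, a halogen swap elsewhere, was within the scatter. With no evidence pointing either way, the expectation for compound 4 is a step of a 1.0-fold higher number from compound 2 to compound 4 (0.02 log units; within the scatter), that is, no change beyond the scatter. Compound 4 is therefore estimated at 17000 nM, with a range from 8000 nM to 40000 nM.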

Compound 4, half-maximal inhibitory concentration: > 50000 nM
Compound 4: only a limit was reported; the forecaster's own chance of this, stated with the estimate: 10%; middle value at least 2.9-fold (0.46 log units) away from the limit.
By their numbers in this assay, from the lowest: compounds 2 and 1 (each within the scatter of the next); then compound 3.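

For the compounds shown here, putting methyl in place of fluoro on this aromatic carbon of the shared core gives an at least 3.0-fold higher number from compound 2 to compound 4 (0.48 log units; beyond the scatter) in this assay, the first step at this place and one that lies beyond the scatter. The swap of one halogen for another elsewhere on the molecule gave only a 1.2-fold lower number from compound 1 to compound 2 (0.06 log units; within the scatter), so this place responds to the change from fluoro to methyl in a way that swap did not. For compound 4 the reported value is a limit of the assay and not a number, so the step gives only a minimum size: the limit of > 50000 nM in this assay, at which 1 of the 4 values shown sits.

With only fluoro and methyl shown at this place, it stays open whether the rise in the number follows from adding the methyl or from removing the fluoro. As far as these compounds go, how a plain hydrogen, a methoxy group or an amine would read out there is also open, as is whether the same step would appear with chloro in place of fluoro on the other ring.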